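This account rests on a few compounds, and the source may have more. Where it says the series, first, only, none or still open, it means among the compounds named here.

Measured compounds:
compound 1 `Cc1cccc(C)c1-c1cccc(COc2ccc(S(=O)(=O)CC(=O)O)cc2)c1` gives 2.49 in a physicochemical assay for lipophilicity, using the shake flask method, in phosphate buffer, measured as octanol-water partition, with a stated time of 24 h, at pH 7.4, tested at 100 uM; on this read-out lower numbers stand for lower lipophilicity and higher numbers for higher lipophilicity;
compound 2 `Cc1cc(OCCCS(C)(=O)=O)cc(C)c1-c1cccc(COc2ccc(S(=O)(=O)CC(=O)O)cc2)c1` gives "not determined" (no result reported) in this assay, that is, no result is reported for it.

Within the data shown here, compound 1 therefore stands as the only compound with a number in this assay, and no step between measured compounds is available. Compound 3 `O=C(O)CS(=O)(=O)c1ccc(OCc2cccc(-c3ccccc3)c2)cc1` differs from it in one place: phenyl in place of 2,6-dimethylphenyl on an aromatic carbon. Among the measured compounds shown here, with no comparable step on hand, a downward step beyond the scatter is expected, since the change removes two methyl groups while the rest of the core is kept. The expected step is a number 0.89 log units lower from compound 1 to compound 3 (beyond the scatter). Compound 3 is thus estimated at 1.6, with a range from 1.1 to 2.1.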

Compound 3, distribution coefficient: 2.13
Compound 3: the middle estimate sits 0.53 log units below what was measured, outside the stated range (above it).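

Replacing 2,6-dimethylphenyl with phenyl on this aromatic carbon, with the rest of the core kept, gives a number 0.36 log units lower from compound 1 to compound 3 (beyond the scatter) in this assay. Among these compounds, this is the first step available here, and it shows that the read-out responds to this change at this position, though only modestly. No measurement shown accounts for the size of this step. Among the compounds shown here, the single step leaves open how a chloro group or an amine on the phenyl ring would shift the read-out. It also leaves open whether the same step would appear on a different core.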